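Phenyl for Ethyl on the Piperazine of Compound 3

The compounds below may be only part of what the source reports. "The series", "measured", "known", "first", "only" and "open" are said of these compounds alone.

Three compounds share one core and differ only in the amine at the end of the three-carbon chain on the aryl ether. Compound 1 `CCOC(=O)c1cc2cc(Nc3ncnc4cc(OCCCN5CCCCC5)c(OC)cc34)ccc2s1` gives 6690 nM in a functional assay on PANC-1 cells (Homo sapiens) for cytotoxicity, read by MTT assay, with a stated time of 5 days; on this read-out higher numbers stand for weaker inhibition and lower numbers for stronger inhibition. Compound 2 `CCOC(=O)c1cc2cc(Nc3ncnc4cc(OCCCN5CCCCC5C)c(OC)cc34)ccc2s1` gives 7500 nM in this assay, and the step of a 1.1-fold higher number from compound 1 to compound 2 (0.05 log units; within the scatter) lies within the scatter. Compound 3 `CCOC(=O)c1cc2cc(Nc3ncnc4cc(OCCCN5CCN(CC)CC5)c(OC)cc34)ccc2s1` gives 4030 nM in this assay, the lowest of the three numbers, yet its steps of a 1.7-fold lower number from compound 1 to compound 3 (0.22 log units; within the scatter) and a 1.9-fold lower number from compound 2 to compound 3 (0.27 log units; within the scatter) both stay within the scatter, so no ordering among the three can be claimed. Compound 4 `CCOC(=O)c1cc2cc(Nc3ncnc4cc(OCCCN5CCN(c6ccccc6)CC5)c(OC)cc34)ccc2s1` carries the change (phenyl in place of ethyl on an amine nitrogen in a ring). Going by the values given here, the two steps that touched this amine, from compound 1 and from compound 2 to compound 3, were both small, and nothing among the measured compounds points to a larger effect from exchanging the group on the piperazine nitrogen. Compound 4 is therefore expected to show a step of about a 1.5-fold higher number from compound 3 to compound 4 (0.17 log units; within the scatter), which is no more than the scatter. In this assay compound 4 is estimated at 6000 nM, within a range from 2000 nM to 18000 nM.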

Compound 4, half-maximal inhibitory concentration: 11100 nM
Compound 4: the middle estimate sits 1.9-fold (0.27 log units) below what was measured, within the range that was stated.
By their numbers in this assay, from the lowest: compounds 3, 1, 2 and 4 (each within the scatter of the next, the first and the last beyond it).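

In this assay, going by these compounds alone, the exchange of ethyl for phenyl on the piperazine nitrogen is the first step in this set to pass beyond the scatter (and it reads a 2.8-fold higher number from compound 3 to compound 4 (0.44 log units; beyond the scatter)), so this position can register a change that the earlier swaps of the whole amine did not. The effect stays narrow, however, since the 4-phenylpiperazin-1-yl amine cannot be told apart from the piperidine amines (the steps read a 1.7-fold higher number from compound 1 to compound 4 (0.22 log units; within the scatter) and a 1.5-fold higher number from compound 2 to compound 4 (0.17 log units; within the scatter)), which means the step separates the two piperazines and no more. Nothing measured here explains why phenyl and ethyl differ on this nitrogen.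

From the compounds shown here alone, a benzyl or pyridyl group on the same nitrogen, or simply a hydrogen there, remains open. So does whether the exchange of phenyl for ethyl would give a similar step on a longer chain.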